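Working notes: two measured analogues, one awaiting measurement

A few compounds are considered here, and "the series" means these few. Any claim that something is new, unique, unknown or untested is made for them only; others in the source may bear on it.

compound 1 `Cc1ccc(C(/C=C/c2ccc(F)cc2)=N\Nc2nncc3ccccc23)cc1` — 5 nM
compound 2 `Clc1ccc(C(/C=C/c2ccccc2)=N\Nc2nncc3ccccc23)cc1` — 6.9 nM

In a functional assay on K562 cells (Homo sapiens) for antiproliferative activity, read by sulforhodamine B assay, with a stated time of 72 h (a higher number here means a weaker inhibitor, a lower number a stronger inhibitor), compound 1 gives 5 nM and compound 2 gives 6.9 nM. Compound 2 holds the higher of the two numbers, but its gap to compound 1 lies within the scatter, so no order between them is claimed. Compound 3 `C(=C/c1ccccc1)\C(=N\Nc1nncc2ccccc12)c1ccccc1` is still to be measured in this assay. Against compound 2 it shows (hydrogen in place of chloro on an aromatic carbon). Among the compounds with values here, no measured pair covers this change. A modest shift toward a higher number is expected, a 1.7-fold higher number from compound 2 to compound 3 (0.24 log units; within the scatter), possibly not beyond the scatter. For compound 3 the expected value is 12 nM, within a range from 5 nM to 30 nM.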

Compound 3, half-maximal inhibitory concentration: 4.4 nM
Compound 3: the middle estimate sits 2.7-fold (0.44 log units) above what was measured, outside the stated range (below it).
By their numbers in this assay, from the lowest: compounds 3, 1 and 2 (each within the scatter of the next).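

Replacing 4-chlorophenyl with phenyl in this assay gives a 1.6-fold lower number from compound 2 to compound 3 (0.20 log units; within the scatter). Within the data shown here, this is the first direct reading at this position, on an aromatic carbon para to a large group: the chloro is not required for a nanomolar value in this pair, and the step shows no gain or loss from it. No measurement on hand accounts for the step.

On these data alone, whether a larger or charged group at this position, such as a methoxy, an amine or a carboxylic acid, would keep the value remains open. As far as these compounds go, the separate contributions of the methyl and fluoro in compound 1 also remain open, as it differs from compound 3 in two places.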